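A benzoyl group replaces the hydroxypropyl chain

A few compounds are considered here, and "the series" means these few. Any claim that something is new, unique, unknown or untested is made for them only; others in the source may bear on it.

Measured in an ADME assay on L929 cells (Mus musculus) for cytotoxicity, read by resazurin assay, with a stated time of 48 h; a higher number here means that more compound is tolerated, a lower number that less compound is tolerated:
- compound 1 `COC(=O)CCn1c2ccc([N+](=O)[O-])cc2c(=O)n1Cc1ccccc1`: > 256000 nM
- compound 2 `O=c1c2cc([N+](=O)[O-])ccc2n(CCCO)n1Cc1ccccc1`: > 256000 nM

Compound 1 gives a limit and no number. Compound 2 gives > 256000 nM in this assay, and this too is only a limit. Together they define (the limit of > 256000 nM in this assay, at which 2 of the 2 values shown sit), so compound 2 has no exact position on the scale.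

The next compound, compound 3 `O=C(c1ccccc1)n1c2ccc([N+](=O)[O-])cc2c(=O)n1Cc1ccccc1`, carries benzoyl in place of 3-hydroxypropyl on an aromatic nitrogen.

Within the data shown here, the only measured step is a step that the two limits leave unreadable from compound 1 to compound 2. It alters the chain on that same nitrogen, but it gives no size to carry over to the new change. The expectation in this assay therefore stays loose: compound 3 should lie close to the limit, with some chance of a readable value on the less tolerated side. The estimate implies an expected at least 1.2-fold lower number from compound 2 to compound 3 (0.10 log units; that floor lies within the scatter), which is a small step downward.

For compound 3 the estimated value is 200000 nM, with an expected range from 60000 nM to 320000 nM.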

Compound 3, concentration lethal to 50% of the cells: 146000 nM
For compound 3 the middle estimate is 1.4-fold (0.14 log units) above the measured one, and the stated range covers the measured number.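

In this assay compound 3 gives 146000 nM, the first actual number for a group on this aromatic nitrogen, so benzoyl is the one group shown here that yields a readable value rather than a limit. Going by these compounds, the change reads as an at least 1.7-fold lower number from compound 2 to compound 3 (0.24 log units; that floor lies within the scatter), and the replacement of 2-(methoxycarbonyl)ethyl reads as an at least 1.7-fold lower number from compound 1 to compound 3 (0.24 log units; that floor lies within the scatter); both figures are floors only, so the true size stays unknown and neither can be claimed as a change beyond the usual scatter. The step between the two earlier compounds still cannot be read, and both of those compounds give only a limit: the limit of > 256000 nM in this assay, at which 2 of the 3 values shown sit.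

It remains open whether the readable value goes with the carbonyl joined to the ring nitrogen or with the six-membered aromatic ring that benzoyl brings, as the compounds shown do not separate the two. An acetyl group or a longer chain ending in a carboxylic acid on the same nitrogen would show whether the value stays near that of compound 3 or returns to the limit.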